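Hydroxy in Place of Octyl on the Amide Nitrogen

This account rests on a few compounds, and the source may have more. Where it says the series, first, only, none or still open, it means among the compounds named here.

Three amides have been measured in an assay on cell membranes for binding affinity to 2-oxoglutarate receptor 1 (Rattus norvegicus), read by radioligand binding; a lower number here means a stronger inhibitor, a higher number a weaker inhibitor. Compound 1, `CCCCCCCCNC(=O)[C@H]1OC(n2cnc3c(N)ncnc32)[C@H](O)[C@@H]1O`, gives 21 nM. Compound 2, `CCCCCCCCCCCCNC(=O)[C@H]1OC(n2cnc3c(N)ncnc32)[C@H](O)[C@@H]1O`, gives 163 nM. Compound 3, `C[C@H]1CC[C@H](NC(=O)[C@H]2O[C@@H](n3cnc4c(N)ncnc43)[C@H](O)[C@@H]2O)CC1`, gives 12.9 nM. Within the data shown here, compound 1 thus stands second highest of the three, within the scatter of compound 3 and well apart from compound 2, the only measured step on this nitrogen's chain being a 7.8-fold higher number from compound 1 to compound 2 (0.89 log units; beyond the scatter). Compound 4, `Nc1ncnc2c1ncn2C1O[C@H](C(=O)NO)[C@@H](O)[C@H]1O`, differs from compound 1 by hydroxy in place of octyl on an amide-type nitrogen. Among the measured compounds shown here, no measured step removes the chain entirely, so the expectation leans on the fact that compound 1, compound 2 and compound 3 all carry a hydrocarbon group there. The step of a 14-fold higher number from compound 1 to compound 4 (1.15 log units; beyond the scatter) is expected. Compound 4 is estimated at 300 nM, ranging from 40 nM to 3000 nM.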

Compound 4, inhibition constant: 41 nM
Estimate against measurement, compound 4: 7.3-fold (0.86 log units) above; the measured number falls inside the stated range.
By their numbers in this assay, from the lowest: compounds 3, 1 and 4 (each within the scatter of the next, the first and the last beyond it); then compound 2.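

Replacing octyl with hydroxy on the amide-type nitrogen gives a 2.0-fold higher number from compound 1 to compound 4 (0.29 log units; within the scatter) in this assay, so this change leaves the number within the scatter. The earlier compounds shown here all carried a hydrocarbon group on this nitrogen, whereas compound 4 shows that such a group is not required for a number in this range. Nothing available explains why two such different groups read alike. Still open, as far as these compounds go, is how a methoxy group or a plain amino group on this nitrogen would read, and whether a carboxylic acid could replace the whole amide.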